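Trifluoromethoxy in Place of tert-Butyl: Expected Cytotoxicity

The source may hold more compounds than are shown below. What is called first, only, known or untested is meant among the compounds shown, and "the series" means these compounds.

The study measures how strongly each compound harms lung-derived cells in an ADME assay on A549 cells (Homo sapiens) for cytotoxicity, read by CellTiter-Glo; on this read-out higher numbers stand for lower toxicity in this test and lower numbers for higher toxicity in this test. Compound 1 `Cc1c(Cc2ccccc2)c(=O)oc2cc(OCC(O)CNc3ccc(Br)cc3)ccc12` does not yield a number: in this assay compound 1 gives > 100000 nM, which is a limit of the test rather than a measured value. Going by the values given here, compound 2 `Cc1c(Cc2ccc(C(C)(C)C)cc2)c(=O)oc2cc(OCC(O)CN3CCC(C(N)=O)CC3)ccc12` is the only compound with a real number: in this assay compound 2 gives 14700 nM. Among the compounds with values here, that value therefore stands alone, its only neighbour being a compound that sits at the limit of > 100000 nM in this assay, at which 1 of the 2 values shown sits.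

Compound 3 `Cc1c(Cc2ccc(OC(F)(F)F)cc2)c(=O)oc2cc(OCC(O)CN3CCC(C(N)=O)CC3)ccc12` differs from compound 2 in one place: trifluoromethoxy in place of tert-butyl on an aromatic carbon. Within the data shown here, no step between two measured compounds shows what such an exchange does in this assay, so no size of shift can be read from earlier results. A small step is expected, a 1.4-fold higher number from compound 2 to compound 3 (0.13 log units; within the scatter), not beyond the scatter of repeated measurements. There is also some chance that compound 3 only reaches the limit of the test. Compound 3 is thus estimated at 20000 nM, with a range from 7000 nM to 60000 nM.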

Compound 3, half-maximal cytotoxic concentration: 68200 nM
Compound 3: the middle estimate sits 3.4-fold (0.53 log units) below what was measured, and the stated range ends below it.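

With everything else held the same, trifluoromethoxy in place of tert-butyl on an aromatic carbon, para to a large group, gives a 4.6-fold higher number from compound 2 to compound 3 (0.67 log units; beyond the scatter) in this assay. This position on the benzyl ring is therefore not indifferent to what it carries: the change moves the read-out towards lower toxicity in this test, even though neither group has a ring, a net charge or a hydrogen-bond donor. This single pair shows the size and direction of the shift but gives no reason for it, and the only other value shown is a limit, not a number: the limit of > 100000 nM in this assay, at which 1 of the 3 values shown sits.

The compounds shown leave open whether the shift is tied to the oxygen, to the fluorine atoms or to the loss of tert-butyl, and a trifluoromethyl group, a nitrile or a carboxylic acid at this position would help to separate these. They also leave open whether the same exchange would give a similar step with a different amine at the other end of the side chain, such as the 4-bromophenyl amine of compound 1.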